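This account rests on a few compounds, and the source may have more. Where it says the series, first, only, none or still open, it means among the compounds named here.

Measured so far:
Compound 1 `C=CC(=O)N1CC(NC(=O)Cn2c(C)c(C(=O)N3CCc4c(cccc4OC)C3)c3cc(Br)cc(C)c32)C1` — in a physicochemical assay for pharmacokinetics, read by LC-MS, in phosphate buffer, at pH 7.4, in the presence of a further agent that is not named here (on this read-out lower numbers stand for a shorter-lived compound and higher numbers for a longer-lived compound), compound 1 gives 1.67 h.
Compound 2 `C=CC(=O)N1CC(NC(=O)Cn2c(C)c(C(=O)N3CCc4c(cccc4OC)C3)c3cc(Br)ccc32)C1` — in this assay compound 2 gives 1.67 h.

Compound 2 stands level with compound 1 on this read-out: the step of no change at the digits printed from compound 1 to compound 2 (within the scatter) lies within the scatter, so the two values do not separate.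

Compound 3 `C=CC(=O)N1CC(NC(=O)Cn2c(C3CC3)c(C(=O)N3CCc4c(cccc4OC)C3)c3cc(Br)ccc32)C1` differs from compound 2 by cyclopropyl in place of methyl on an aromatic carbon. Among the compounds with values here, no measured step touches this position, so nothing bears on it directly. Within the data shown here, the one step in hand, no change at the digits printed from compound 1 to compound 2 (within the scatter), concerns a methyl on an aromatic carbon elsewhere in the shared core and left the half-life unchanged. Because no change at the digits printed from compound 1 to compound 2 (within the scatter) lay within the scatter, no step beyond the scatter is expected here in either direction, and the expected step is a 1.0-fold higher number from compound 2 to compound 3 (0.01 log units; within the scatter). Compound 3 is therefore estimated at 1.7 h, with a range from 0.8 h to 3.5 h.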

Compound 3, half-life: 1.67 h
Beside the measured number, compound 3's estimate is 1.0-fold (0.01 log units) above it, within the range that was stated.
By their numbers in this assay, from the lowest: compounds 1, 2 and 3 (each within the scatter of the next).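

At the aromatic carbon next to the ring nitrogen, cyclopropyl in place of methyl gives no change at the digits printed from compound 2 to compound 3 (within the scatter) in this assay. Within the data shown here, this is the first reading at this position, and the one earlier step concerned a methyl elsewhere on the shared core: here a larger group carrying a three-membered ring of carbon only does not separate from methyl on this read-out. Nothing at hand bears on why the half-life stays level.

Still open, as far as these compounds go, is whether a group of another kind at this position, such as an amine, a carboxylic acid or a longer chain, would also stay within the scatter of methyl. Also open is whether cyclopropyl reads the same with the further methyl of compound 1 on the shared core, since it is shown only on the core of compound 2.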